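This account rests on a few compounds, and the source may have more. Where it says the series, first, only, none or still open, it means among the compounds named here.

Measured compounds in a functional assay on SK-HEP1 cells (Homo sapiens) for antiproliferative activity, read by sulforhodamine B assay; on this read-out higher numbers stand for weaker inhibition of growth and lower numbers for stronger inhibition of growth:

compound 1 `COc1ccc(C(=O)Nc2nc3cc(C)cc(C)c3s2)cc1`: > 10 ug/mL, a limit of the assay
compound 2 `COc1ccc(C(=O)Nc2nc3cc(OC)ccc3s2)cc1`: > 10 ug/mL, a limit of the assay
compound 3 `Cc1cc(C)c2sc(NC(=O)c3ccc([N+](=O)[O-])cc3)nc2c1`: 1.74 ug/mL

Two of the three measured values are limits rather than numbers, namely (the limit of > 10 ug/mL in this assay, at which 2 of the 3 values shown sit). Only compound 3 gives a number in this assay.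

Among the measured compounds shown here, the one measured step on a single position is nitro in place of methoxy on an aromatic carbon, which in this assay brought an at least 5.7-fold lower number from compound 1 to compound 3 (0.75 log units; beyond the scatter). Since compound 1 sits at a limit, the true size of that step is not known; only its floor is.

Compound 2 and compound 1 share the amide and the methoxy-bearing ring, but the difference between the two cores is not broken down here.

Compound 4 `COc1ccc2sc(NC(=O)c3ccc([N+](=O)[O-])cc3)nc2c1` is not yet measured. It stands to compound 2 as compound 3 stands to compound 1: nitro in place of methoxy on an aromatic carbon, at the same place by the same description, so this is the same change made on the core of compound 2.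

For compound 4 in this assay the step of an at least 3.3-fold lower number from compound 2 to compound 4 (0.52 log units; beyond the scatter) is expected, resting on the measured at least 5.7-fold lower number from compound 1 to compound 3 (0.75 log units; beyond the scatter) and on compound 2 sitting at a limit > 10 ug/mL. The estimate for compound 4 in this assay is 3 ug/mL, expected to fall between 1 ug/mL and 10 ug/mL, with a real chance that only a limit is returned, as for compound 2.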

Compound 4, concentration for 50% growth inhibition: > 10 ug/mL
Compound 4: a limit, no number; the forecaster's own chance of this, stated with the estimate: 30%; middle value at least 3.3-fold (0.52 log units) away from the limit.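

Compound 4 gives > 10 ug/mL in this assay, a limit of the assay and not a number. Compound 2 sits at the same limit, so no step from compound 2 to compound 4 can be read: the limit of > 10 ug/mL in this assay, at which 3 of the 4 values shown sit.

Left open is whether nitro in place of methoxy on an aromatic carbon changes growth inhibition at all on the core of compound 2.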